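Benzyl in Place of the Amide Chain: Expected Effect

A few compounds are considered here, and "the series" means these few. Any claim that something is new, unique, unknown or untested is made for them only; others in the source may bear on it.

Three compounds have been measured in a functional assay on PC-3 cells (Homo sapiens) for inhibition, read by MTT assay, with a stated time of 48 h; on this read-out lower numbers stand for stronger inhibition and higher numbers for weaker inhibition:
Compound 1 `COc1cc(-c2nc3cc(/C=C4\SC(=O)NC4=O)ccc3[nH]2)cc(OC)c1OC` gives 12000 nM.
Compound 2 `COc1cc(-c2nc3cc(/C=C4\SC(=O)N(CC(=O)N5CCOCC5)C4=O)ccc3[nH]2)cc(OC)c1OC` gives 5940 nM.
Compound 3 `COc1cc(-c2nc3cc(/C=C4\SC(=O)N(CC(=O)N5CCCC5)C4=O)ccc3[nH]2)cc(OC)c1OC` gives 8370 nM.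

Compound 3 stands second highest of these three numbers; both steps that end at it, a 1.4-fold higher number from compound 2 to compound 3 (0.15 log units; within the scatter) and a 1.4-fold lower number from compound 1 to compound 3 (0.16 log units; within the scatter), lie within the usual scatter, so the three cannot be ordered with confidence. Compound 4 `COc1cc(-c2nc3cc(/C=C4\SC(=O)N(Cc5ccccc5)C4=O)ccc3[nH]2)cc(OC)c1OC` differs from compound 3 by phenyl in place of (pyrrolidin-1-yl)carbonyl on a saturated chain carbon bound to an amide-type nitrogen in a ring. The measured steps that bear on this change are those that put a group on the same ring nitrogen: a 2.0-fold lower number from compound 1 to compound 2 (0.31 log units; beyond the scatter) and a 1.4-fold lower number from compound 1 to compound 3 (0.16 log units; within the scatter), both small, and the swap at the chain end, a 1.4-fold higher number from compound 2 to compound 3 (0.15 log units; within the scatter), which lies within the scatter. Going by the values given here, none of the measured compounds carries a phenyl at this place, so direct evidence is absent. The expected step in this assay is therefore small, with no direction beyond the scatter, as a 1.2-fold lower number from compound 3 to compound 4 (0.08 log units; within the scatter). Compound 4 is estimated at 7000 nM, with a range from 2500 nM to 20000 nM.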

Compound 4, half-maximal inhibitory concentration: 2500 nM
Compound 4: middle estimate off by 2.8-fold (0.45 log units), on the high side; the measured number falls inside the stated range.
By their numbers in this assay, from the lowest: compound 4; then compounds 2, 3 and 1 (each within the scatter of the next, the first and the last beyond it).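

In this assay, benzyl on the amide-type nitrogen in a ring gives a lower number than every earlier group at this place: a 3.3-fold lower number from compound 3 to compound 4 (0.52 log units; beyond the scatter) and a 2.4-fold lower number from compound 2 to compound 4 (0.38 log units; beyond the scatter) and a 4.8-fold lower number from compound 1 to compound 4 (0.68 log units; beyond the scatter) all lie beyond the scatter. The two amide chains could not be told apart, yet replacing their carbonyl-bound ring with phenyl moves the number clearly, so what sits at the end of the group on this nitrogen matters, not only whether the nitrogen carries a group. Nothing at hand explains why this change has that effect.

The compounds shown cannot tell whether the aromatic ring itself is needed, as a comparison with cyclohexylmethyl would. They also leave open how a longer chain such as 2-phenylethyl, or a benzyl carrying chlorine or methoxy on its ring, would read out.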